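The source may report more compounds than this note shows. Statements on the series, on what has been measured and on what is new or still open speak of the compounds shown alone.

Compound 1 `Cc1cc(NS(=O)(=O)c2ccc(N3C(=O)/C(=C/c4coc5ccccc5c4=O)N=C3c3ccc(Cl)cc3)cc2)no1` stands at a limit rather than at a number in a functional assay on A549 cells (Homo sapiens) for cytotoxicity, read by sulforhodamine B assay, with a stated time of 72 h; on this read-out higher numbers stand for weaker inhibition and lower numbers for stronger inhibition. In this assay compound 1 gives > 100000 nM, which is a limit of the assay. Compound 2 `Cc1cc(C)nc(NS(=O)(=O)c2ccc(NC3=NC(=O)/C(=C\c4coc5ccccc5c4=O)S3)cc2)n1` likewise stops at a limit, since in this assay compound 2 gives > 100000 nM. Among the measured compounds shown here, compound 3 `NS(=O)(=O)c1ccc(NC2=NC(=O)/C(=C\c3coc4ccccc4c3=O)S2)cc1` is the one measured compound with a true number, and in this assay compound 3 gives 2230 nM. That change, an at least 44-fold lower number from compound 2 to compound 3 (1.65 log units; beyond the scatter), removed a heteroaryl group from the sulfonamide nitrogen altogether. Compound 4 `O=C1/C(=C/c2coc3ccccc3c2=O)N=C(c2ccc(Cl)cc2)N1c1ccc(S(=O)(=O)Nc2ncccn2)cc1` does not: pyrimidin-2-yl in place of 5-methyl-1,2-oxazol-3-yl on a sulfonamide nitrogen. Compound 4 still carries an aromatic ring on that nitrogen, as pyrimidin-2-yl in place of 5-methyl-1,2-oxazol-3-yl on a sulfonamide nitrogen shows; no drop beyond the scatter is expected. Compound 4 is therefore estimated at 100000 nM (range 30000 nM to 300000 nM), an expected step of a number no higher from compound 1 to compound 4 (the limit leaves the size open).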

Compound 4, half-maximal inhibitory concentration: 59000 nM
Beside the measured number, compound 4's estimate is 1.7-fold (0.23 log units) above it; measured number inside the range.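

On the core of compound 1, replacing one aromatic ring with another on the sulfonamide nitrogen gives a true number in this assay, but the floor of the step lies within the scatter (an at least 1.6-fold lower number from compound 1 to compound 4 (0.22 log units; that floor lies within the scatter)). This ring-for-ring change therefore shows no drop beyond the scatter, unlike the earlier loss of the ring on another core. Its full size cannot be read because compound 1 sits at a limit: the limit of > 100000 nM in this assay, at which 2 of the 4 values shown sit.

Still open, as far as these compounds go, is whether hydrogen or an acetyl group on that nitrogen would give a lower number on the core of compound 1.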